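A few compounds are considered here, and "the series" means these few. Any claim that something is new, unique, unknown or untested is made for them only; others in the source may bear on it.

Of the compounds shown here, three with a shared core have been measured in a functional assay on MGC-803 cells (Homo sapiens) for inhibition, read by MTT assay, with a stated time of 48 h; on this read-out lower numbers stand for stronger inhibition and higher numbers for weaker inhibition. Compound 1 `C/C=C/C(=O)N(Cc1cccc(O)c1)c1cc(OC)c(OC)c(OC)c1`, which carries a 3-hydroxyphenyl group, gives 14100 nM. Compound 2 `C/C=C/C(=O)N(Cc1ccc(OC)cc1)c1cc(OC)c(OC)c(OC)c1`, with a 4-methoxyphenyl group instead, gives 450 nM, and compound 3 `C/C=C/C(=O)N(Cc1ccc(OC)c(F)c1)c1cc(OC)c(OC)c(OC)c1`, with a 3-fluoro-4-methoxyphenyl group, gives 1650 nM. Compound 3 therefore holds the second highest of the three numbers.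

The next compound is compound 4 `C/C=C/C(=O)N(Cc1ccc(OC)c(Cl)c1)c1cc(OC)c(OC)c(OC)c1`, and the change is small: chloro in place of fluoro on an aromatic carbon.

Among the compounds with values here, no measured pair makes this exact swap, so the evidence is indirect. Two steps replace the whole group: a 31-fold lower number from compound 1 to compound 2 (1.50 log units; beyond the scatter), which is large, and an 8.5-fold lower number from compound 1 to compound 3 (0.93 log units; beyond the scatter), which is modest. Both also change the methoxy and hydroxy groups, so they say little here. The closest guide is a 3.7-fold higher number from compound 2 to compound 3 (0.56 log units; beyond the scatter), a modest step made at the same aromatic carbon. It shows, for this one pair, that a change at this carbon can move the number, but a single step cannot fix a trend.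

The expected step is therefore small: a 1.2-fold higher number from compound 3 to compound 4 (0.08 log units; within the scatter), an estimate that leans slightly upward and stays within the usual scatter. For compound 4 the estimated value is 2000 nM, with an expected range from 700 nM to 5500 nM.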

Compound 4, half-maximal inhibitory concentration: 7100 nM
For compound 4 the middle estimate is 3.6-fold (0.55 log units) below the measured one, and the stated range ends below it.
By their numbers in this assay, from the lowest: compound 2; then compound 3; then compounds 4 and 1 (each within the scatter of the next).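

In this assay the identity of the halogen at this aromatic carbon matters: swapping fluoro for chloro gives a 4.3-fold higher number from compound 3 to compound 4 (0.63 log units; beyond the scatter) even though each group counts as one heavy atom, with no hydrogen-bond donors or acceptors. Measured against hydrogen at the same carbon, fluoro gives a 3.7-fold higher number from compound 2 to compound 3 (0.56 log units; beyond the scatter) while chloro gives a 16-fold higher number from compound 2 to compound 4 (1.20 log units; beyond the scatter) and so, across these three compounds, the number rises in the order hydrogen, fluoro, chloro. Chloro also removes the clear advantage over the 3-hydroxyphenyl group: a 2.0-fold lower number from compound 1 to compound 4 (0.30 log units; within the scatter) lies within the usual scatter, so compound 4 and compound 1 cannot be told apart here, although compound 3 and compound 2 both stand clearly apart from compound 1.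

Nothing available here gives a reason for these steps.

A bromo group, a methyl group or an amine at this carbon would test whether the rise from hydrogen through fluoro to chloro continues or is limited to these three groups.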